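A few compounds are considered here, and "the series" means these few. Any claim that something is new, unique, unknown or untested is made for them only; others in the source may bear on it.

Compound 1 `CCOC(=O)N1CCC(=NNC(=O)c2ccc(F)cc2)CC1` gives in a toxicity assay on BJ cells (Homo sapiens) for cytotoxicity, read by MTT assay, with a stated time of 24 h (a higher number here means a weaker inhibitor, a lower number a stronger inhibitor), only a limit of the assay, > 400000 nM.
Compound 2 `CCOC(=O)N1CCC(=NNC(=O)c2ccc([N+](=O)[O-])cc2)CC1` gives in this assay only a limit, > 400000 nM.
Compound 3 `O=C(NN=C1CC(c2ccccc2)NC(c2ccccc2)C1)c1ccc(F)cc1` gives in this assay only a limit, > 400000 nM.

Compound 3 therefore stands nowhere on a scale of numbers: it sits at the limit of > 400000 nM in this assay, at which 3 of the 3 values shown sit, alongside the two other compounds, and none of the three is separated from the others by anything readable. For the measured compounds named here, the one step that connects two measured compounds, from compound 1 to compound 2, is a step that the two limits leave unreadable from compound 1 to compound 2, a replacement of one small group by another on the same kind of aromatic carbon; it leaves the size of that change unknown.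

Compound 4 `O=C(NN=C1CC(c2ccccc2)NC(c2ccccc2)C1)c1ccc(C(F)(F)F)cc1` differs from compound 3 by trifluoromethyl in place of fluoro on an aromatic carbon. Going by the values given here, the only measured step that resembles this change, from compound 1 to compound 2, is itself unreadable, so nothing measured here gives a direction or a size for the step in this assay. The expectation is therefore that compound 4 will again sit at the limit, and the step of a number no higher from compound 3 to compound 4 (the limit leaves the size open) is estimated to be none beyond the scatter. For compound 4 the estimate in this assay is 400000 nM, with a range from 150000 nM to 1000000 nM, most likely reported only as a limit.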

Compound 4, half-maximal inhibitory concentration: > 400000 nM
Compound 4 ended at the assay's limit; the forecaster's own chance of this, stated with the estimate: 80%; the middle value lies on the limit itself.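

Compound 4, like compound 3, is reported in this assay only as a limit, so no step can be read between these two compounds, and the replacement of fluoro by trifluoromethyl has no readable size: the limit of > 400000 nM in this assay, at which 4 of the 4 values shown sit.

The compounds shown leave open how the four rank against one another in this assay, and whether any aromatic substituent changes the result.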